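A few compounds are considered here, and "the series" means these few. Any claim that something is new, unique, unknown or untested is made for them only; others in the source may bear on it.

In an ADME assay on Vero cells (Chlorocebus sabaeus) for cytotoxicity, read by MTT assay, with a stated time of 72 h (a lower number here means a stronger inhibitor, a higher number a weaker inhibitor), three compounds that share one core have been measured. Compound 1 (`CC1CN(c2nc3c(cc2[N+](=O)[O-])c(=O)c(C(=O)O)cn3C2CC2)CC(C)O1`) gives > 160000 nM, which is a limit of the assay and not a number. Compound 2 (`O=C(O)c1cn(C2CC2)c2nc(N3CCC(n4c(=O)[nH]c5cc(Cl)ccc54)CC3)c([N+](=O)[O-])cc2c1=O`) gives 55500 nM. Compound 3 (`O=C(O)c1cn(C2CC2)c2nc(N3CCC4(CC3)OCCO4)c([N+](=O)[O-])cc2c1=O`) gives 150000 nM, the higher of the two actual numbers, with compound 2 lying lower by more than the usual scatter.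

Compound 4 (`CC1(C)COCN1c1nc2c(cc1[N+](=O)[O-])c(=O)c(C(=O)O)cn2C1CC1`) differs from compound 3 at one place, an aromatic carbon ortho to a nitro group, where 4,4-dimethyl-1,3-oxazolidin-3-yl enters: a group of 7 heavy atoms (5 carbon, 1 nitrogen, 1 oxygen; one five-membered non-aromatic ring with 2 hetero atoms) in place of a group of 10 heavy atoms (7 carbon, 1 nitrogen, 2 oxygen; one five-membered non-aromatic ring with 2 hetero atoms, one six-membered non-aromatic ring with 1 hetero atom), on an aromatic carbon.

The closest guide is an at least 1.0-fold lower number from compound 1 to compound 3 (0.02 log units; that floor lies within the scatter), which was also an exchange of one group on that aromatic carbon. That step starts from a limit, (the limit of > 160000 nM in this assay, at which 1 of the 3 values shown sits), so it gives only a floor. Compound 2, at 55500 nM, shows that a different group in this place can go with a clearly lower number, so some drop cannot be ruled out. Even so, the step expected here is a 1.3-fold lower number from compound 3 to compound 4 (0.10 log units; within the scatter), with no change beyond the scatter in this assay. For compound 4 the estimated value is 120000 nM, with an expected range from 60000 nM to 200000 nM.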

Compound 4, half-maximal inhibitory concentration: 167000 nM
Estimate against measurement, compound 4: 1.4-fold (0.14 log units) below, and the stated range covers the measured number.
By their numbers in this assay, from the lowest: compound 2; then compounds 3 and 4 (each within the scatter of the next).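

In this assay, this aromatic carbon ortho to a nitro group now has a step between two actual numbers: a 1.1-fold higher number from compound 3 to compound 4 (0.05 log units; within the scatter). The group with two non-aromatic rings can thus give way to the smaller 4,4-dimethyl-1,3-oxazolidin-3-yl, with its single five-membered ring and one hydrogen-bond acceptor fewer, without any change beyond the scatter, so neither the second ring nor that acceptor is needed to keep the number where it stands. The step from compound 1 to compound 4 cannot be read, because compound 1 stands at a limit and not at an actual number: the limit of > 160000 nM in this assay, at which 1 of the 4 values shown sits.

The compounds shown leave open what sets the larger group of compound 2 apart, at 55500 nM, and whether a simple piperazin-1-yl or an open-chain diethylamino group in this place would go with a number like that one or stay with those of compound 3 and compound 4. They also leave open how the number would respond if the nitro group gave way to an amine or the carboxylic acid to an amide.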